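Fluoro for Trifluoromethyl on a Somatostatin Agonist Core

This account rests on a few compounds, and the source may have more. Where it says the series, first, only, none or still open, it means among the compounds named here.

Compound 1 `Cc1cc(C)cc(-c2cncc(-c3nc4cc(C(F)(F)F)ccc4[nH]3)c2N2CCC(N)CC2)c1`: 0.014 nM
Compound 2 `Cc1nc(C(=O)Nc2cncc(-c3cc(Cl)cc(Cl)c3)c2N2CCC(N)CC2)c(C)o1`: 0.47 nM
Compound 3 `Cc1cc(C(=O)Nc2cncc(-c3cc(Cl)cc(Cl)c3)c2N2CCC(N)CC2)n(C)n1`: 0.041 nM

In a functional assay on CHO-K1 cells for agonist activity at somatostatin receptor type 2 (Homo sapiens), read by cAMP accumulation, with a stated time of 30 min (on this read-out higher numbers stand for an effect only at larger amounts of compound and lower numbers for an effect already at smaller amounts), compound 1 gives the lowest number of the three; compound 3 stands higher, and compound 2 higher still. Within the data shown here, the one measured step, an 11-fold lower number from compound 2 to compound 3 (1.06 log units; beyond the scatter), concerns the group on the carbonyl carbon of the amide and does not touch the position varied here. Compound 4 `Cc1cc(C)cc(-c2cncc(-c3nc4cc(F)ccc4[nH]3)c2N2CCC(N)CC2)c1` differs from compound 1 by fluoro in place of trifluoromethyl on an aromatic carbon. Among the measured compounds shown here, no measured pair shows this change, so the expectation for compound 4 rests on compound 1 alone. A modest rise is expected for compound 4, a 2.1-fold higher number from compound 1 to compound 4 (0.33 log units; beyond the scatter), with little support either way. Compound 4 is therefore estimated at 0.03 nM, within a range from 0.008 nM to 0.12 nM.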

Compound 4, half-maximal effective concentration: 0.013 nM
Estimate against measurement, compound 4: 2.3-fold (0.36 log units) above; the measured number falls inside the stated range.
By their numbers in this assay, from the lowest: compounds 4 and 1 (each within the scatter of the next); then compound 3; then compound 2.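

In this assay, fluoro in place of trifluoromethyl on this aromatic carbon gives a 1.1-fold lower number from compound 1 to compound 4 (0.03 log units; within the scatter), so compound 4 and compound 1 cannot be told apart. The earlier compounds shown here, whose one measured step lay on the carbonyl side, could not show that this position takes either group without a difference beyond the scatter. Nothing on hand accounts for this result. As far as these compounds go, whether plain hydrogen, an amine or a carboxylic acid would read the same at this place stays open, so how much this position accepts remains unknown.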